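The compounds below may be only part of what the source reports. "The series", "measured", "known", "first", "only" and "open" are said of these compounds alone.

Measured so far in a functional assay on B16 cells (Mus musculus) for inhibition; on this read-out lower numbers stand for stronger inhibition and higher numbers for weaker inhibition:
Compound 1 `Cc1ccc(CNC(=O)/C=C/c2ccc(O)c(O)c2)cc1` gives 3700 nM
Compound 2 `O=C(/C=C/c1ccc(O)c(O)c1)NCc1ccc(Cl)cc1` gives 1800 nM

Compound 2 holds the lower number of the two. Compound 3 `NS(=O)(=O)c1ccc(CNC(=O)/C=C/c2ccc(O)c(O)c2)cc1` is next, with sulfamoyl in place of chloro on an aromatic carbon, para to a large group: sulfamoyl in place of chloro on an aromatic carbon. Within the data shown here, only one measured step bears on this carbon, the modest 2.1-fold lower number from compound 1 to compound 2 (0.31 log units; beyond the scatter), for chloro in place of methyl. Among the measured compounds shown here, no sulfamoyl compound has been measured, so the direction is weakly supported. The expected step is a 1.6-fold higher number from compound 2 to compound 3 (0.19 log units; within the scatter), modest and toward a higher number. Compound 3 is estimated at 2800 nM, within a range of 900 nM to 9000 nM.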

Compound 3, half-maximal inhibitory concentration: > 40000 nM
Compound 3: a limit, no number; the forecaster's own chance of this, stated with the estimate: 7%; at least 14-fold (1.15 log units) between middle value and limit.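

In this assay compound 3 gives > 40000 nM, a limit of the assay and not a number. Among these compounds, on this aromatic carbon, para to a large group, sulfamoyl brings a large step, an at least 22-fold higher number from compound 2 to compound 3 (1.34 log units; beyond the scatter) and an at least 10-fold higher number from compound 1 to compound 3 (1.03 log units; beyond the scatter), where the change among the earlier compounds was only modest. The full size of the step stays unknown, as the reading stops at the limit: the limit of > 40000 nM in this assay, at which 1 of the 3 values shown sits.

Open, from the compounds shown here alone, is whether the sulfonyl part or the nitrogen of sulfamoyl carries the step. A methylsulfonyl group or a carboxylic acid on this carbon would separate the two.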